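The source may report more compounds than this note shows. Statements on the series, on what has been measured and on what is new or still open speak of the compounds shown alone.

Measured so far:
compound 1 `Cn1c(-c2ccc(F)cc2)nc2c(NC3CCCC3)ncnc21`: 6.2 nM
compound 2 `Cc1ccc(-c2nc3c(NC4CCCC4)ncnc3n2C)cc1`: 8 nM

In an assay on CHO cells for displacement of a labelled ligand from adenosine receptor A1 (Homo sapiens), read by scintillation counting, with a stated time of 3 h (a lower number here means a stronger inhibitor, a higher number a weaker inhibitor), compound 2 gives the highest of the two numbers; its nearest neighbour is compound 1, and the step from compound 1 to compound 2 is a 1.3-fold higher number from compound 1 to compound 2 (0.11 log units; within the scatter), a swap of one substituent on the phenyl for another that the data do not resolve from scatter. Compound 3 `Cn1c(-c2ccccc2Cl)nc2c(NC3CCCC3)ncnc21` is still to be measured. The change from compound 2 is 2-chlorophenyl in place of 4-methylphenyl on an aromatic carbon. Within the data shown here, only the one measured step bears on it, and that step exchanged substituents of the phenyl without moving them; the change to compound 3 alters both the substituent and its place on the ring, for which no measured step exists. The expectation is a modest weakening, a 1.9-fold higher number from compound 2 to compound 3 (0.27 log units; within the scatter), with wide uncertainty. Compound 3 is expected to give 15 nM, within 4 nM to 60 nM.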

Compound 3, inhibition constant: 37 nM
For compound 3 the middle estimate is 2.5-fold (0.39 log units) below the measured one, and the stated range covers the measured number.
By their numbers in this assay, from the lowest: compounds 1 and 2 (each within the scatter of the next); then compound 3.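

In this assay the aryl group on the aromatic carbon between two ring nitrogen atoms now responds beyond the scatter: 2-chlorophenyl in place of 4-methylphenyl gives a 4.6-fold higher number from compound 2 to compound 3 (0.67 log units; beyond the scatter) and 2-chlorophenyl in place of 4-fluorophenyl gives a 6.0-fold higher number from compound 1 to compound 3 (0.78 log units; beyond the scatter) on the same core. The earlier exchange of 4-fluorophenyl for 4-methylphenyl gave only a 1.3-fold higher number from compound 1 to compound 2 (0.11 log units; within the scatter) and showed no such sensitivity, so this position is not indifferent to every change of the phenyl group. Nothing available explains the loss.

Because substituent and ring place change together, the steps cannot separate the chlorine from its place; 4-chlorophenyl and 2-methylphenyl would be the compounds that separate them. Going by these compounds, how an amine or a carboxylic acid on the phenyl ring would read in this assay also remains open.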